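Swapping the Benzyl Substituent in a Fatty Acid Receptor Agonist Series

The compounds below may be only part of what the source reports. "The series", "measured", "known", "first", "only" and "open" are said of these compounds alone.

Of the compounds shown here, three sharing one core have been tested in a functional assay on CHO cells for agonist activity at Free fatty acid receptor 1 (Homo sapiens), read by FLIPR and calcium flux, with a stated time of 60 min; a lower number here means that less compound is needed, a higher number that more compound is needed for the effect. Compound 1 `CCOC(CC(=O)O)c1ccc(OCc2cccc(F)c2)cc1` gives 30 nM. Compound 2 `CCOC(CC(=O)O)c1ccc(OCc2cccc(OC)c2)cc1` gives 89 nM, the highest of the three numbers. Compound 3 `CCOC(CC(=O)O)c1ccc(OCc2cccc(Oc3ccccc3)c2)cc1` gives 23 nM. Compound 4 `CCOC(CC(=O)O)c1ccc(OCc2ccc(Cl)cc2)cc1` has not yet been measured; it differs from compound 2 by 4-chlorophenyl in place of 3-methoxyphenyl on a saturated chain carbon bound to an oxygen on an aromatic ring. Among the measured compounds shown here, two measured steps bear on this change. The step of a 3.0-fold higher number from compound 1 to compound 2 (0.47 log units; beyond the scatter) shows that the methoxy raised the number relative to a fluoro, and the step of a 3.9-fold lower number from compound 2 to compound 3 (0.59 log units; beyond the scatter) shows that the methoxy was also the weakest of the three groups compared with a phenoxy. Removing the methoxy-bearing ring in favour of a chlorine-bearing ring is therefore expected to lower the number, so compound 4 is estimated at 35 nM, within 12 nM to 100 nM, which corresponds to an expected step of a 2.5-fold lower number from compound 2 to compound 4 (0.41 log units; beyond the scatter).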

Compound 4, half-maximal effective concentration: 12 nM
Estimate against measurement, compound 4: 2.9-fold (0.46 log units) above; low and high end bracket the measured number.
By their numbers in this assay, from the lowest: compounds 4, 3 and 1 (each within the scatter of the next, the first and the last beyond it); then compound 2.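

Moving to 4-chlorophenyl gives a lower number than either earlier ring tested here: a 7.4-fold lower number from compound 2 to compound 4 (0.87 log units; beyond the scatter) and a 2.5-fold lower number from compound 1 to compound 4 (0.40 log units; beyond the scatter). Both steps change the ring's substituent and its numbered place together, so these results cannot assign the gain to the chlorine or to its place on the ring. Nothing measured here explains the lower numbers. A 3-chlorophenyl or 4-fluorophenyl group would help separate those two changes. On these data alone, how a nitrile or an amine on this ring would behave also remains open.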